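The source may hold more compounds than are shown below. What is called first, only, known or untested is meant among the compounds shown, and "the series" means these compounds.

Values in a functional assay on HCT-116 cells (Homo sapiens) for antiproliferative activity, read by MTT assay, with a stated time of 72 h; a lower number here means a stronger inhibitor, a higher number a weaker inhibitor:

- compound 1 `O=C1COc2ccc(-c3cnc(Cl)c(NS(=O)(=O)c4ccc(F)cc4)c3)cc2N1C1CCCCC1`: > 40000 nM
- compound 2 `COc1ncc(-c2ccc3c(c2)N(C2CCCCC2)C(=O)CO3)cc1NS(=O)(=O)c1ccc(F)cc1`: > 40000 nM
- compound 3 `Cc1ccc(N2C(=O)COc3ccc(-c4cccc(NS(=O)(=O)c5ccc(F)cc5)c4)cc32)cc1`: 35600 nM

Compound 2 stands at > 40000 nM, which is a limit of the assay and not a number. Compound 1 sits at that same place, (the limit of > 40000 nM in this assay, at which 2 of the 3 values shown sit). Compound 3, at 35600 nM, is the only one of the three with a true number, and that number is still in a weak range for this assay.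

The next compound, compound 4 `COc1ncc(-c2ccc3c(c2)N(C(C)C)C(=O)CO3)cc1NS(=O)(=O)c1ccc(F)cc1`, keeps everything in compound 2 except one group: isopropyl in place of cyclohexyl on an amide-type nitrogen in a ring. In plain terms, this puts isopropyl in place of cyclohexyl on an amide-type nitrogen in a ring.

Among the compounds with values here, the only measured step is a step that the two limits leave unreadable from compound 1 to compound 2. It concerns methoxy in place of chloro on an aromatic carbon, so it offers no size to carry over to this change. No measured pair isolates the group on the amide-type nitrogen, so the data give no reason to predict a direction. What is expected is an at least 1.1-fold lower number from compound 2 to compound 4 (0.05 log units; that floor lies within the scatter), with no clear change beyond the scatter. For compound 4 the estimated value in this assay is 35000 nM, with an expected range from 10000 nM to 60000 nM.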

Compound 4, half-maximal inhibitory concentration: 19200 nM
Estimate against measurement, compound 4: 1.8-fold (0.26 log units) above; measured number inside the range.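

Isopropyl in place of cyclohexyl on the amide-type nitrogen in a ring gives, in this assay, an at least 2.0-fold lower number from compound 2 to compound 4 (0.31 log units; beyond the scatter), the first step among these compounds with a readable size, and it shows that the group at this position can move the read-out, with the lower number on the side of the group with fewer heavy atoms and no ring. Compound 2 stands at > 40000 nM, which is a limit of the assay and not a number. The step is therefore only a floor, and the real difference may be larger, because the starting point of the step is such a limit: the limit of > 40000 nM in this assay, at which 2 of the 4 values shown sit.

From the compounds shown here alone, this position rests on a single pair, so it remains open whether the number would keep falling with a shorter group such as ethyl or methyl, or with a plain hydrogen on that nitrogen, and how a longer chain ending in an amine or a carboxylic acid would behave. Compound 4, at 19200 nM, is still a weak inhibitor in this assay, so it is also unknown whether any change at this position alone could bring the number down into a strong range.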